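The compounds below may be only part of what the source reports. "The series", "measured", "known", "first", "only" and "open" are said of these compounds alone.

Of the compounds shown here, two from this set have been tested in an assay on isolated protein for inhibition of Trypsin (Homo sapiens); a higher number here means a weaker inhibitor, a lower number a stronger inhibitor. Compound 1, `CCOc1cc(C(Nc2ccc3c(N)nccc3c2)C(=O)NS(=O)(=O)c2cccc(N)c2)ccc1OC(C)C`, is one of them. In this assay compound 1 gives > 5000 nM, which is a limit of the assay rather than a measured number. Compound 2, `CCOc1cc([C@@H](Nc2ccc3c(N)nccc3c2)C(=O)NS(=O)(=O)c2cccc(S(N)(=O)=O)c2)ccc1OC(C)C`, is the other. In this assay compound 2 gives > 5000 nM, again only a limit. Both results therefore rest at the same point, (the limit of > 5000 nM in this assay, at which 2 of the 2 values shown sit), and nothing separates the two compounds on the numbers at hand.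

Compound 3, `CCOc1cc(C(Nc2ccc3c(N)nccc3c2)C(=O)NS(=O)(=O)c2cccc(S(N)(=O)=O)c2)ccc1OC(C)C`, is the next compound to be measured. Its relation to compound 2 is the two compounds have the same atoms and bonds; at least one stereo element is drawn with a configuration in one of them and without one in the other: 1 of 1 stereo elements differ; a stereocentre at a saturated chain carbon is drawn R in compound 2 and without a configuration in compound 3: the two compounds have the same atoms and bonds, and the stereocentre at a saturated chain carbon that is drawn R in compound 2 is drawn without a configuration in compound 3. Going by the values given here, no step between measured compounds exists to set a size for such a change. The expected step that the limit leaves unreadable from compound 2 to compound 3 is no change beyond the scatter. For compound 3 the estimate in this assay is 10000 nM, within a range of 4000 nM to 40000 nM, and most likely the assay will again report only a limit.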

Compound 3, inhibition constant: > 5000 nM
Compound 3: a limit, no number; the forecaster's own chance of this, stated with the estimate: 85%; the middle value lies beyond the limit too.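

In this assay compound 3 gives > 5000 nM as a limit of the assay and not a number. No step can be read among compound 1, compound 2 and compound 3, which all rest at one point: the limit of > 5000 nM in this assay, at which 3 of the 3 values shown sit.

The compounds shown leave open whether the sulfamoyl in place of amino, or the configuration drawn at the stereocentre, changes inhibition of this enzyme at all.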